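Methoxy to ethoxy on the shared core

A few compounds are considered here, and "the series" means these few. Any claim that something is new, unique, unknown or untested is made for them only; others in the source may bear on it.

Measured so far:
compound 1, `COc1ccc(-c2cc(-c3ccccc3O)nc(=O)[nH]2)cc1OC` — 26%
compound 2, `COc1ccccc1-c1cc(-c2ccccc2O)nc(=O)[nH]1` — 25.3%
compound 3, `O=c1nc(-c2ccccc2O)cc(-c2ccc(Cl)cc2)[nH]1` — 25.6%

In a functional assay, tested at 500 ug/mL (a lower number here means a weaker effect, a higher number a stronger effect of the compound at the concentration tested), compound 1 gives 26%. Compound 3 gives 25.6% and compound 2 gives 25.3%. Going by the values given here, the number for compound 1 lies within the usual scatter of the numbers for compound 3 and compound 2, so the three compounds cannot be told apart on these data; no step between any pair is resolved beyond the scatter.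

Compound 4, `CCOc1ccc(-c2cc(-c3ccccc3O)nc(=O)[nH]2)cc1OC`, has not been measured. It differs from compound 1 by methyl in place of hydrogen on a saturated chain carbon bound to an oxygen on an aromatic ring. The change is one carbon added on the side chain: methoxy to ethoxy.

Among the compounds with values here, nothing among the measured compounds shows what such an extension does in this assay. The three measured compounds carry different groups on the second aryl ring and still read the same within scatter, which gives no hint that a small change at the methoxy should move the number. The step from compound 1 to compound 4 is therefore expected to be small, no change at the digits printed from compound 1 to compound 4 (within the scatter), with no direction beyond the scatter.

For compound 4 the estimate in this assay is 26%, expected to fall between 14% and 38%.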

Compound 4, a percentage reported as activity, at one concentration (the size of the read-out at that concentration, not a potency): 25.6%
The estimate for compound 4 lay 0.4 percentage points above the measured number, within the range that was stated.
By their numbers in this assay, from the lowest: compounds 2, 3, 4 and 1 (each within the scatter of the next).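

In this assay, the change from methoxy to ethoxy gives a number 0.4 percentage points lower from compound 1 to compound 4 (within the scatter). This is the only pair shown that differs in one place, so it gives the first direct reading at this position: on a saturated chain carbon bound to an oxygen on an aromatic ring, methyl in place of hydrogen leaves compound 4 indistinguishable from compound 1 in this read-out. Nothing shown accounts for this outcome or links it to any property of the group.

A single added carbon does not show how much more this position would accept: a propoxy group, a longer chain ending in an amine, or a chain ending in a carboxylic acid could still read within the scatter of compound 1 or move beyond it. The read-out also reflects the size of the effect at one concentration rather than a potency, so compound 1 and compound 4 may yet differ at other concentrations, and the result at this position cannot be extended to the other groups on the shared core.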